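This account rests on a few compounds, and the source may have more. Where it says the series, first, only, none or still open, it means among the compounds named here.

Measured in a functional assay on the whole organism (B cells) with Mus musculus as the target; on this read-out higher numbers stand for larger maximal responses and lower numbers for smaller maximal responses:

compound 1, `COc1ccc(Cn2c(=O)n(C3OC(CO)[C@@H](O)[C@H]3O)c3nc(N)nc(O)c32)cc1`: 44%
compound 2, `CN(C)CCCn1c(=O)n(C2OC(CO)[C@@H](O)[C@H]2O)c2nc(N)nc(O)c21`: 83%
compound 3, `Cn1c(=O)n(C2OC(CO)[C@@H](O)[C@H]2O)c2nc(N)nc(O)c21`: 99%

Of the three, compound 3 stands highest in this assay, and both gaps to it lie beyond the scatter: the smaller is a number 16 percentage points higher from compound 2 to compound 3 (beyond the scatter), the larger is a number 55 percentage points higher from compound 1 to compound 3 (beyond the scatter). Compound 4, `Nc1nc(O)c2c(n1)n(C1OC(CO)[C@@H](O)[C@H]1O)c(=O)n2Cc1ccccc1`, differs from compound 3 by phenyl in place of hydrogen on a saturated chain carbon bound to an aromatic nitrogen. For the measured compounds named here, two measured steps bear on this change. Both alter the same saturated chain carbon bound to an aromatic nitrogen, and in both the loss of a larger group in favour of hydrogen raised the maximal response: a number 16 percentage points higher from compound 2 to compound 3 (beyond the scatter) and, far more strongly, a number 55 percentage points higher from compound 1 to compound 3 (beyond the scatter). The step to compound 4 runs the other way and adds a group of the same kind as the 4-methoxyphenyl of compound 1, so a large fall is expected. Compound 4 is therefore estimated at 50% in this assay, with a range of 30% to 72%. That estimate means an expected a number 49 percentage points lower from compound 3 to compound 4 (beyond the scatter).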

Compound 4, largest response reached (reported as maximal response), in percent of the reference or control that the assay uses: 110%
Estimate against measurement, compound 4: 60 percentage points below; the measured number lies above the stated range.
By their numbers in this assay, from the lowest: compound 1; then compound 2; then compound 3; then compound 4.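

In this assay the step of a number 11 percentage points higher from compound 3 to compound 4 (beyond the scatter) shows that phenyl on the saturated chain carbon bound to an aromatic nitrogen need not lower the response, so a larger group at this place is not in itself a loss, and the step of a number 27 percentage points higher from compound 2 to compound 4 (beyond the scatter) points the same way. Hydrogen in place of methoxy on an aromatic carbon gives a number 66 percentage points higher from compound 1 to compound 4 (beyond the scatter) and is the largest step shown, so the low response of compound 1 goes with the methoxy and not with the aromatic ring as such. No accompanying measurement accounts for these steps.

Going by these compounds, whether an amine or a hydroxyl on that same aromatic carbon would lower the response as methoxy does remains open. So does whether a longer chain, such as phenethyl in place of benzyl, would hold the response.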